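Changing the Group on an Aromatic Nitrogen

A few compounds are considered here, and "the series" means these few. Any claim that something is new, unique, unknown or untested is made for them only; others in the source may bear on it.

Compound 1 `COc1cc(C(=O)c2ccc3c(ccn3C)c2)cc(OC)c1OC`: 13.6 nM
Compound 2 `COc1cc(C(=O)c2ccc3c(ccn3C(C)C)c2)cc(OC)c1OC`: 1800 nM
Compound 3 `COc1cc(C(=O)c2ccc3c(ccn3CC(=O)O)c2)cc(OC)c1OC`: not yet measured

In a functional assay on KB cells (Homo sapiens) for inhibition, with a stated time of 72 h (a higher number here means a weaker inhibitor, a lower number a stronger inhibitor), compound 2 at 1800 nM stands highest of the two. Carboxymethyl in place of isopropyl on an aromatic nitrogen leads to compound 3 (carboxymethyl in place of isopropyl on an aromatic nitrogen). Within the data shown here, one measured step bears on this nitrogen: isopropyl in place of methyl gave a 130-fold higher number from compound 1 to compound 2 (2.12 log units; beyond the scatter) and counts as large. Among the measured compounds shown here, no measured compound carries carboxymethyl, so the evidence is thin. A modest further rise in this assay is expected, not a return towards compound 1. The expected change is a 1.7-fold higher number from compound 2 to compound 3 (0.22 log units; within the scatter) in size. Compound 3 is estimated at 3000 nM (expected range 500 nM to 15000 nM).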

Compound 3, half-maximal inhibitory concentration: 520 nM
Compound 3: the middle estimate sits 5.8-fold (0.76 log units) above what was measured, within the range that was stated.
By their numbers in this assay, from the lowest: compound 1; then compound 3; then compound 2.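

In this assay, heavy-atom count alone does not order the groups on this nitrogen: carboxymethyl has more heavy atoms than isopropyl, yet gives a 3.5-fold lower number from compound 2 to compound 3 (0.54 log units; beyond the scatter). Much of the strength seen with methyl is still missing, with a 38-fold higher number from compound 1 to compound 3 (1.58 log units; beyond the scatter). No measurement here explains either step. Open, going by these compounds, is where an ethyl group would fall between methyl and isopropyl. Also open, on these data alone, is how an amide or a longer chain ending in a carboxylic acid would compare with carboxymethyl in this assay.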